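The compounds below may be only part of what the source reports. "The series", "measured", "known", "first", "only" and "open" are said of these compounds alone.

Measured compounds:
Compound 1, `COc1cc2cc(C(=O)NCCCc3ccccc3)c(=O)oc2cc1OCCCOc1no[n+]([O-])c1S(=O)(=O)c1ccccc1`, 760 nM
Compound 2, `COc1cc2cc(C(=O)NCCCc3ccc(F)cc3)c(=O)oc2cc1OCCCOc1no[n+]([O-])c1S(=O)(=O)c1ccccc1`, 690 nM
Compound 3, `COc1ccc(NC(=O)c2cc3cc(OC)c(OCCCOc4no[n+]([O-])c4S(=O)(=O)c4ccccc4)cc3oc2=O)cc1`, 730 nM

All three were tested in a functional assay on MDA-MB-231 cells (Homo sapiens) for inhibition, read by MTT assay, with a stated time of 48 h; a lower number here means a stronger inhibitor, a higher number a weaker inhibitor. The three numbers lie close together: compound 3 sits second highest of the three, with compound 1 nearest and compound 2 furthest, and every gap between them falls within the scatter. Compound 4, `COc1cc2cc(C(=O)Nc3ccc(F)cc3)c(=O)oc2cc1OCCCOc1no[n+]([O-])c1S(=O)(=O)c1ccccc1`, has not yet been measured. It differs from compound 3 in one place: fluoro in place of methoxy on an aromatic carbon, on the ring that hangs from the amide nitrogen, para to a large group.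

For the measured compounds named here, no measured step swaps methoxy for fluoro directly. The closest guide is a 1.1-fold lower number from compound 1 to compound 2 (0.04 log units; within the scatter), where a fluoro entered on the same kind of ring position and the number hardly moved. The swap of the whole amide substituent, a 1.0-fold lower number from compound 1 to compound 3 (0.02 log units; within the scatter) and a 1.1-fold higher number from compound 2 to compound 3 (0.02 log units; within the scatter), also left the number essentially unchanged. On this evidence the expected step is no change at the digits printed from compound 3 to compound 4 (within the scatter), with no movement beyond the scatter in either direction. Compound 4 is therefore estimated at 730 nM, within a range of 400 nM to 1350 nM.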

Compound 4, half-maximal inhibitory concentration: 1200 nM
The estimate for compound 4 lay 1.6-fold (0.22 log units) below the measured number; the range from low to high includes it.
By their numbers in this assay, from the lowest: compounds 2, 3, 1 and 4 (each within the scatter of the next).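

In this assay the swap of methoxy for fluoro on this aromatic carbon, para to a large group, gives a 1.6-fold higher number from compound 3 to compound 4 (0.22 log units; within the scatter) and so offers the first direct test of this position, showing that this change does not move the number beyond the scatter. With 4-fluorophenyl on the amide nitrogen, the comparison with the 3-(4-fluorophenyl)propyl group gives a 1.7-fold higher number from compound 2 to compound 4 (0.24 log units; within the scatter) and the comparison with the 3-phenylpropyl group gives a 1.6-fold higher number from compound 1 to compound 4 (0.20 log units; within the scatter) so these swaps of the whole amide substituent also cannot be told apart from repeat-measurement noise. No supporting measurement is available to explain these numbers.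

From the compounds shown here alone, whether an amine or a carboxylic acid at this ring position would shift the number beyond the scatter remains open. So does the effect of a longer chain between the amide nitrogen and the 4-fluorophenyl ring.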